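The source may report more compounds than this note shows. Statements on the series, on what has been measured and on what is new or still open speak of the compounds shown alone.

Two compounds have so far been taken through an ADME assay on PBMC cells (Homo sapiens) for cytotoxicity, with a stated time of 5 days; on this read-out lower numbers stand for stronger inhibition and higher numbers for weaker inhibition. Compound 1 `Cc1ccsc1C(=O)/C=C/c1ccc(N2CCCCC2)cc1` gives 26400 nM in this assay. Compound 2 `Cc1ccc(C2=NNC(c3ccc(N4CCCCC4)cc3)C2)s1` gives 86400 nM in this assay, the higher of the two numbers, and its gap to compound 1 lies beyond the scatter. Compound 3 `Ic1ccc(C2=NNC(c3ccc(N4CCCCC4)cc3)C2)s1` has not yet been measured. It differs from compound 2 by iodo in place of methyl on an aromatic carbon of the five-membered aromatic ring, next to the ring sulfur. Going by the values given here, no measured pair shows this same change, so there is no step to lean on. Among the compounds with values here, with only two numbers at hand, the expected step is a 1.4-fold lower number from compound 2 to compound 3 (0.16 log units; within the scatter), a modest move toward a lower number that may not clear the scatter. Compound 3 is estimated at 60000 nM, with a range from 20000 nM to 150000 nM.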

Compound 3, half-maximal inhibitory concentration: > 100000 nM
Compound 3: only a limit was reported; the forecaster's own chance of this, stated with the estimate: 25%; middle value at least 1.6-fold (0.22 log units) from the limit.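

In this assay compound 3 gives > 100000 nM, which is a limit of the assay and not a number. The change from 5-methylthiophen-2-yl to 5-iodothiophen-2-yl is read as an at least 1.1-fold higher number from compound 2 to compound 3 (0.06 log units; that floor lies within the scatter), so iodo gives no sign of the move toward a lower number, although this floor alone does not establish a real rise. The earlier compounds offered no reading of any change on this aromatic carbon next to the ring sulfur, and the new reading bounds the step on one side only: the limit of > 100000 nM in this assay, at which 1 of the 3 values shown sits.

Going by these compounds, how far compound 3 lies past the limit stays open, and with it the true size of the step. Also open, on these data alone, is whether chloro, an amine or a carboxylic acid at this position would give a lower number than compound 2 does.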